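Swapping the halogenated phenyl ring on a brominated core

The compounds below may be only part of what the source reports. "The series", "measured", "known", "first", "only" and "open" are said of these compounds alone.

Measured compounds and their values:
- compound 1 `OC(CCn1nc2c(Br)c(Br)c(Br)c(Br)c2n1)c1ccc(F)cc1`: 109%
- compound 2 `COc1cccc(C(O)CCn2nc3c(Br)c(Br)c(Br)c(Br)c3n2)c1`: 97%
- compound 3 `OC(CCn1nc2c(Br)c(Br)c(Br)c(Br)c2n1)c1cccc(Cl)c1`: 107%

Among the measured compounds shown here, all three share a tetrabrominated core joined through a short chain to a carbon that carries both a hydroxyl and an aromatic ring; only that ring differs. In a functional assay on MCF7 cells (Homo sapiens) for antiproliferative activity, read by MTT assay, with a stated time of 48 h, tested at 12.5 uM (on this read-out higher numbers stand for a weaker effect at the one concentration tested and lower numbers for a stronger effect), compound 3 stands second highest of the three numbers. Its nearest neighbour is compound 1, with a number 2 percentage points lower from compound 1 to compound 3 (within the scatter); the furthest is compound 2, with a number 10 percentage points higher from compound 2 to compound 3 (within the scatter). Neither of these steps exceeds the scatter, so compound 1, compound 2 and compound 3 cannot be told apart on this read-out. Only a number 12 percentage points lower from compound 1 to compound 2 (beyond the scatter) goes beyond the scatter, and it is modest.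

Compound 4 `OC(CCn1nc2c(Br)c(Br)c(Br)c(Br)c2n1)c1ccc(Br)cc1` differs from compound 3 by 4-bromophenyl in place of 3-chlorophenyl on a saturated chain carbon bound to an oxygen on a saturated carbon and a saturated chain carbon. For the measured compounds named here, the steps that bear on this change are the two halogen swaps, a number 2 percentage points lower from compound 1 to compound 3 (within the scatter) and a number 10 percentage points higher from compound 2 to compound 3 (within the scatter), both within the scatter. Since no halogen change on this ring has moved this assay beyond the scatter, compound 4 is expected to show a step of a number 2 percentage points lower from compound 3 to compound 4 (within the scatter), that is, no change beyond the scatter. The estimate for compound 4 in this assay is therefore 105%, with a range from 92% to 118%.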

Compound 4, a percentage reported as activity, at one concentration (the size of the read-out at that concentration, not a potency): 107%
The estimate for compound 4 lay 2 percentage points below the measured number, and the stated range covers the measured number.
By their numbers in this assay, from the lowest: compounds 2, 3, 4 and 1 (each within the scatter of the next, the first and the last beyond it).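

In this assay, 4-bromophenyl in place of 3-chlorophenyl gives no change at the digits printed from compound 3 to compound 4 (within the scatter), so changing the halogen and its printed ring position together leaves no readable mark, and bromo in place of fluoro on an aromatic carbon likewise gives a number 2 percentage points lower from compound 1 to compound 4 (within the scatter). The 3-methoxyphenyl ring, the only non-halogen ring shown, cannot be separated from the new compound either, since 4-bromophenyl in its place gives a number 10 percentage points higher from compound 2 to compound 4 (within the scatter); the one step beyond the scatter remains a number 12 percentage points lower from compound 1 to compound 2 (beyond the scatter), and compound 4 does not add a second one. Nothing measured here offers a reason for this flat picture on the aromatic ring at this saturated chain carbon.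

These compounds leave open whether a group of a different kind on this ring, such as an amine or a carboxylic acid, would shift the number clearly beyond the scatter. They also leave open what a longer chain in place of the present one would do, and whether a result at this single concentration would hold at others.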